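The compounds below may be only part of what the source reports. "The series", "measured", "known", "first", "only" and "open" are said of these compounds alone.

Going by the values given here, compound 3 `NCCNc1nonc1/C(=N/O)Nc1ccc(F)c(Br)c1` is the one member of this small set with a true number in an ADME assay on liver (Rattus norvegicus) for metabolic stability, read by LC-MS, using S9 fraction and NADPH, with a stated time of 30 min, tested at 5 uM, in the presence of a further agent that is not named here; a lower number here means slower removal, a higher number faster removal of the compound: compound 3 gives 15 mL/min/kg. Compound 1 `O/N=C(\Nc1ccc(F)c(Br)c1)c1nonc1NCc1ccccc1` reaches only a limit of the assay, > 36.6 mL/min/kg. Compound 2 `COCCNc1nonc1/C(=N/O)Nc1ccc(F)c(Br)c1` likewise reaches only a limit, > 36.6 mL/min/kg. Two steps lead to compound 3, an at least 2.4-fold lower number from compound 1 to compound 3 (0.38 log units; beyond the scatter) and an at least 2.4-fold lower number from compound 2 to compound 3 (0.38 log units; beyond the scatter), while a step that the two limits leave unreadable from compound 1 to compound 2. Compound 4 `CS(=O)(=O)NCCNc1nonc1/C(=N/O)Nc1ccc(F)c(Br)c1` differs from compound 3 by methylsulfonyl in place of hydrogen on an amine nitrogen. Among the compounds with values here, no measured step changes an amine nitrogen in this way, so the expectation rests on the measured value of compound 3 alone. For compound 4 a step of a 1.3-fold higher number from compound 3 to compound 4 (0.12 log units; within the scatter) is expected, within the scatter. Compound 4 is thus estimated at 20 mL/min/kg, between 10 mL/min/kg and 36 mL/min/kg.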

Compound 4, clearance: 25 mL/min/kg
Beside the measured number, compound 4's estimate is 1.3-fold (0.10 log units) below it; the range from low to high includes it.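

In this assay, methylsulfonyl in place of hydrogen on the amine nitrogen gives a 1.7-fold higher number from compound 3 to compound 4 (0.22 log units; within the scatter), which shows that this nitrogen can carry the added group and still give a true number rather than a limit. The other two steps are an at least 1.4-fold lower number from compound 2 to compound 4 (0.16 log units; that floor lies within the scatter) and an at least 1.4-fold lower number from compound 1 to compound 4 (0.16 log units; that floor lies within the scatter). Compound 1 and compound 2 each sit at a limit, and these two steps are floors only: the limit of > 36.6 mL/min/kg in this assay, at which 2 of the 4 values shown sit.

Still open, as far as these compounds go, is whether acetyl or methyl on this nitrogen, or a longer chain in place of 2-aminoethyl, would stay as close to compound 3.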